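Methyl for Fluoro on the Aryl Ring of Compound 3

This account rests on a few compounds, and the source may have more. Where it says the series, first, only, none or still open, it means among the compounds named here.

Measured compounds:
- compound 1, `COc1cccc(-c2noc(C3CC(=O)N(c4ccc(Cl)cc4)C3)n2)c1`, 4800 nM
- compound 2, `Cc1cccc(-c2noc(C3CC(=O)N(c4ccc(Cl)c(Cl)c4)C3)n2)c1`, 390 nM
- compound 3, `O=C1CC(c2nc(-c3cccc(F)c3)no2)CN1c1ccc(Cl)cc1`, 630 nM

In an in vitro functional assay on HEK293-A cells for positive allosteric modulation of metabotropic glutamate receptor 5 (Homo sapiens), read by FLIPR and calcium flux (on this read-out higher numbers stand for an effect only at larger amounts of compound and lower numbers for an effect already at smaller amounts), compound 3 stands second highest of the three numbers. Its nearest neighbour is compound 2, whose value lies within the scatter of that of compound 3, so the two cannot be told apart; the furthest is compound 1, separated from compound 3 by a 7.6-fold lower number from compound 1 to compound 3 (0.88 log units; beyond the scatter).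

Compound 4, `Cc1cccc(-c2noc(C3CC(=O)N(c4ccc(Cl)cc4)C3)n2)c1`, differs from compound 3 in one place: methyl in place of fluoro on an aromatic carbon. Among the compounds with values here, only one measured step touches this position, the one from compound 1 to compound 3, in which fluoro replaced methoxy and gave a 7.6-fold lower number from compound 1 to compound 3 (0.88 log units; beyond the scatter). That step tells that this position matters, but it compares methoxy and fluoro, not fluoro and methyl. Compound 2 carries the same methyl as compound 4, yet it also carries a second chloro on the other ring, so its comparison with compound 3 rests on two changes at once; its value and that of compound 3 lie within the scatter of each other. On this basis the expected step in this assay from compound 3 to compound 4 is a 1.3-fold lower number from compound 3 to compound 4 (0.10 log units; within the scatter), which is not beyond the scatter. Compound 4 is therefore estimated at 500 nM, with a range from 170 nM to 1500 nM.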

Compound 4, half-maximal effective concentration: 170 nM
Estimate against measurement, compound 4: 2.9-fold (0.47 log units) above; the measured number falls inside the stated range.
By their numbers in this assay, from the lowest: compound 4; then compounds 2 and 3 (each within the scatter of the next); then compound 1.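

In this assay, going from 3-fluorophenyl to 3-methylphenyl gives a 3.7-fold lower number from compound 3 to compound 4 (0.57 log units; beyond the scatter) and so separates two small groups at this ring position, a contrast the earlier step between methoxy and fluoro could not show. With methoxy, fluoro and methyl now all read on the same core carrying one chloro, the order of the numbers runs from methyl, the lowest, through fluoro to methoxy, and the full span is a 28-fold lower number from compound 1 to compound 4 (1.45 log units; beyond the scatter) for this single change. Within the data shown here, compound 4 also isolates the second chloro of compound 2 for the first time: a 2.3-fold lower number from compound 2 to compound 4 (0.36 log units; beyond the scatter) when hydrogen takes the place of that chloro, so on this methyl-bearing core the extra chloro does not bring the number down.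

The three groups compared here say nothing about how a chloro, an ethyl, an amine or a plain hydrogen would read at the same position, or whether the effect of the second chloro would hold with fluoro or methoxy on the ring. Nothing shown here explains why methyl gives a lower number than fluoro.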